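Working notes: methyl for fluoro on compound 2

The source may hold more compounds than are shown below. What is called first, only, known or untested is meant among the compounds shown, and "the series" means these compounds.

Values from a functional assay on HepG2 cells (Homo sapiens) for antiproliferative activity, read by colorimetric assay and MTT assay, with a stated time of 48 h (on this read-out higher numbers stand for weaker inhibition and lower numbers for stronger inhibition), so far:
- compound 1 `Cc1ccc(S(=O)(=O)NC(=O)c2ccncc2)cc1` at 20200 nM
- compound 2 `O=C(NS(=O)(=O)c1ccc(F)cc1)c1ccccn1` at 8500 nM

Compound 2 holds the lower of the two numbers, and so the stronger inhibition, at 8500 nM on this read-out. The gap between this number and that of compound 1 at 20200 nM lies beyond the usual scatter. The next compound to be measured is compound 3 `Cc1ccc(S(=O)(=O)NC(=O)c2ccccn2)cc1` and it differs from compound 2 in one place: methyl in place of fluoro on an aromatic carbon and, in words, methyl in place of fluoro on an aromatic carbon, para to a large group.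

Within the data shown here, no two measured compounds differ in only one place, so the series offers no direct guide to the size of this exchange. In this assay no step beyond the scatter is expected, with at most a slight drift toward a higher number. The estimated change is a 1.3-fold higher number from compound 2 to compound 3 (0.11 log units; within the scatter) and this is expected to stay within the usual scatter. For compound 3 the expected value is 11000 nM with an estimated range from 4500 nM to 24000 nM in this assay series.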

Compound 3, half-maximal inhibitory concentration: 12100 nM
For compound 3 the middle estimate is 1.1-fold (0.04 log units) below the measured one; low and high end bracket the measured number.
By their numbers in this assay, from the lowest: compounds 2, 3 and 1 (each within the scatter of the next, the first and the last beyond it).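

In this assay the exchange of fluoro for methyl on an aromatic carbon, para to a large group, gives a 1.4-fold higher number from compound 2 to compound 3 (0.15 log units; within the scatter) and so stays within the scatter; at this position, the two groups cannot be told apart on this read-out. Among these compounds, compound 3 also provides the first reading of the attachment on the carbonyl carbon, where pyridin-2-yl in place of pyridin-4-yl gives a 1.7-fold lower number from compound 1 to compound 3 (0.22 log units; within the scatter) and also stays within the scatter, so compound 3 links compound 1 and compound 2 through two single exchanges, neither of which produces a step beyond the scatter. The data at hand offer no measurement that would account for either step.

Only fluoro and methyl are shown at the aromatic position, so it remains open whether an amine, a carboxylic acid, a methoxy group or a longer chain there would also stay within the scatter. On the carbonyl carbon, pyridin-3-yl or a plain phenyl ring would show whether the attachment can move the number beyond the scatter at all.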